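This account rests on a few compounds, and the source may have more. Where it says the series, first, only, none or still open, it means among the compounds named here.

Of the compounds shown here, three of one shared core have been measured in an assay on isolated protein (Mus musculus) for inhibition of IL15-IL15 receptor (Homo sapiens), read by resazurin assay, with stated times of 30 min and 2.5 days; on this read-out higher numbers stand for weaker inhibition and lower numbers for stronger inhibition. Compound 1 `CN(C(=O)CCCCCCCSc1nnc(Cc2nn(C)c(=O)c3ccccc23)n1C)c1ccc(Cl)cc1Cl` gives 11900 nM. Compound 2 `Cn1c(Cc2nn(C)c(=O)c3ccccc23)nnc1SCCCCCCCC(=O)Nc1ccc(F)cc1F` gives 2300 nM, and compound 3 `Cc1ccc(NC(=O)CCCCCCCSc2nnc(Cc3nn(C)c(=O)c4ccccc34)n2C)c(Cl)c1` gives 2300 nM. Compound 3 is level with compound 2, and together they give the lowest numbers of the three; compound 1 stands furthest from compound 3, with a 5.2-fold lower number from compound 1 to compound 3 (0.71 log units; beyond the scatter).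

Compound 4 `Cn1c(Cc2nn(C)c(=O)c3ccccc23)nnc1SCCCCCCCC(=O)Nc1ccc(O)cc1O` has not yet been measured. It differs from compound 3 in one place: 2,4-dihydroxyphenyl in place of 2-chloro-4-methylphenyl on an amide-type nitrogen. The step that bears most directly on this change is the one between the two amide-bearing compounds, no change at the digits printed from compound 2 to compound 3 (within the scatter), where one aromatic ring on the amide nitrogen was swapped for another without a shift beyond the scatter. The steps of a 5.2-fold lower number from compound 1 to compound 2 (0.71 log units; beyond the scatter) and a 5.2-fold lower number from compound 1 to compound 3 (0.71 log units; beyond the scatter) show that this end of the molecule does matter, but both involve a change at the nitrogen itself as well. Within the data shown here, no measured pair shows a ring carrying hydroxyl groups, so the effect of the two entering hydroxyls is unknown. Compound 4 is therefore expected to change little, with a 1.3-fold higher number from compound 3 to compound 4 (0.12 log units; within the scatter) roughly within the scatter, and its estimated value is 3000 nM, between 1000 nM and 10000 nM.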

Compound 4, half-maximal inhibitory concentration: 17000 nM
The estimate for compound 4 lay 5.7-fold (0.75 log units) below the measured number, outside the stated range (above it).
By their numbers in this assay, from the lowest: compounds 2 and 3 (each within the scatter of the next); then compounds 1 and 4 (each within the scatter of the next).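

The ring on the amide nitrogen tolerates less than the earlier swap of rings suggested: putting 2,4-dihydroxyphenyl there weakens inhibition, which shows as a higher number on this read-out (a 7.4-fold higher number from compound 3 to compound 4 (0.87 log units; beyond the scatter); a 7.4-fold higher number from compound 2 to compound 4 (0.87 log units; beyond the scatter)). This change of ring alone costs about as much as the earlier change that altered both the ring and the amide nitrogen, leaving the new compound within the scatter of the compound with the methylated nitrogen (a 1.4-fold higher number from compound 1 to compound 4 (0.15 log units; within the scatter)). No measurement available here explains why the two hydroxyl groups have this effect.

On these data alone, the two hydroxyl groups enter together, so it remains open whether one alone would carry the loss. Also open, as far as these compounds go, is how a ring bearing methoxy groups, an amine or a carboxylic acid would read, and what a methyl on the amide nitrogen would do alongside 2,4-dihydroxyphenyl.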